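The compounds below may be only part of what the source reports. "The series", "measured", "known", "first", "only" and "open" are said of these compounds alone.

Measured in a functional assay on SGC-7901 cells (Homo sapiens) for antiproliferative activity, read by sulforhodamine B assay, with a stated time of 72 h; on this read-out lower numbers stand for stronger inhibition and higher numbers for weaker inhibition:
Compound 1 `S=C(N/N=C/c1ccc2ccccc2n1)Nc1ccc(Br)cc1` gives 69400 nM.
Compound 2 `Cc1ccccc1NC(=S)N/N=C/c1ccc2ccccc2n1` reaches only a limit of the assay, > 100000 nM.
Compound 3 `Cc1ccc(NC(=S)N/N=C/c2ccc3ccccc3n2)cc1` gives 92900 nM.

Compound 3 holds the higher of the two numbers actually read; its nearest neighbour is compound 1, and a 1.3-fold higher number from compound 1 to compound 3 (0.13 log units; within the scatter) keeps the pair within the scatter, so no order between them can be stated. Compound 2 sits at the limit (the limit of > 100000 nM in this assay, at which 1 of the 3 values shown sits), and both an at least 1.4-fold higher number from compound 1 to compound 2 (0.15 log units; that floor lies within the scatter) and an at least 1.0-fold lower number from compound 2 to compound 3 (0.03 log units; that floor lies within the scatter) have floors inside the scatter. Across the three, whether the ring on the amide-type nitrogen carries bromo or methyl, as 4-bromophenyl, 2-methylphenyl or 4-methylphenyl, the read-out barely moves.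

Compound 4 `S=C(NCc1ccccc1)N/N=C/c1ccc2ccccc2n1` differs from compound 3 by benzyl in place of 4-methylphenyl on an amide-type nitrogen. Among the compounds with values here, none of the measured steps exchanges the ring on that nitrogen for benzyl; they only vary what the ring carries, and all stayed within the scatter. Nothing in the series points one way, so for this assay this assay the expectation is a step no larger than the scatter, with wide uncertainty since the change is of a kind not yet sampled. The expected step is a 1.0-fold lower number from compound 3 to compound 4 (0.01 log units; within the scatter). Compound 4 is estimated at 90000 nM, between 30000 nM and 300000 nM.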

Compound 4, half-maximal inhibitory concentration: 53700 nM
Compound 4: the middle estimate sits 1.7-fold (0.22 log units) above what was measured; the measured number falls inside the stated range.
By their numbers in this assay, from the lowest: compounds 4, 1 and 3 (each within the scatter of the next). At a limit, above all of these: compound 2.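

Benzyl in place of 4-methylphenyl on the amide-type nitrogen is the first exchange here of the group itself rather than of what its ring carries, and in this assay it gives a 1.7-fold lower number from compound 3 to compound 4 (0.24 log units; within the scatter). Against the 4-bromophenyl group the exchange gives a 1.3-fold lower number from compound 1 to compound 4 (0.11 log units; within the scatter), so the position tolerates this change of attachment without a readable shift, and compound 1, compound 3 and compound 4 cannot be put in any order. The value of compound 2 is a limit and not a number, and the exchange of its 2-methylphenyl group for benzyl yields only a floor, an at least 1.8-fold lower number from compound 2 to compound 4 (0.27 log units; that floor lies within the scatter), from which no order follows: the limit of > 100000 nM in this assay, at which 1 of the 4 values shown sits.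

From the compounds shown here alone, whether a longer chain such as 2-phenylethyl, or a ring carrying an amine or a carboxylic acid, on this nitrogen would move the read-out beyond the scatter remains open. The shared core is the same in all compounds shown, and its part in the read-out stays open too.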